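The compounds below may be only part of what the source reports. "The series", "measured", "known", "first", "only" and "open" are said of these compounds alone.

Two compounds of this series have been run in a functional assay on BGC-823 cells (Homo sapiens) for antiproliferative activity, read by MTT assay, tested at 5 uM; on this read-out lower numbers stand for a weaker effect and higher numbers for a stronger effect at the one concentration tested. For the measured compounds named here, compound 1 `COc1ccc(OC)c(C2OC(c3cc(OC)c(OC)c(OC)c3)=NN2C(C)=O)c1` gives 18.2%, and compound 2 `COc1cc(C2=NN(C(C)=O)C(c3ccc(F)cc3)O2)cc(OC)c1OC` gives 13.3%; the single measured step, a number 4.9 percentage points lower from compound 1 to compound 2 (within the scatter), leaves compound 2 within the scatter of compound 1. Compound 3 `COc1cc(C2=NN(C(C)=O)C(c3cccc(F)c3)O2)cc(OC)c1OC` differs from compound 2 only in 3-fluorophenyl in place of 4-fluorophenyl on a saturated ring carbon. Going by the values given here, no measured step bears directly on this change, and the one step seen on that saturated ring carbon stayed within the scatter, so no shift beyond the scatter is expected, a number 0.7 percentage points higher from compound 2 to compound 3 (within the scatter). Compound 3 is therefore estimated at 14%, between 5% and 25%.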

Compound 3, a percentage reported as inhibition, at one concentration (the size of the read-out at that concentration, not a potency): 37.7%
The estimate for compound 3 lay 23.7 percentage points below the measured number, and the stated range ends below it.
By their numbers in this assay, from the lowest: compounds 2 and 1 (each within the scatter of the next); then compound 3.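

Moving the fluorine alone, with the same atoms throughout, matters on this saturated ring carbon: this assay shows a number 24.4 percentage points higher from compound 2 to compound 3 (beyond the scatter), the first step here beyond the scatter. The 3-fluorophenyl group also stands clear of 2,5-dimethoxyphenyl, with a number 19.5 percentage points higher from compound 1 to compound 3 (beyond the scatter). No evidence at hand accounts for the gap between the two fluorophenyl isomers.

From the compounds shown here alone, whether a chlorophenyl or an aminophenyl group on this carbon would match compound 3 remains open. Going by these compounds, with a single tested concentration, the potency of compound 3 also remains open.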